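Swapping a Side Group on a Sodium/Hydrogen Exchanger Inhibitor

The source may hold more compounds than are shown below. What is called first, only, known or untested is meant among the compounds shown, and "the series" means these compounds.

Compound 1, `CS(=O)(=O)c1cc(C(=O)N=C(N)N)ccc1Oc1cccnc1`, gives 76 nM in a functional assay for inhibition of sodium/hydrogen exchanger (Oryctolagus cuniculus); on this read-out higher numbers stand for weaker inhibition and lower numbers for stronger inhibition.
Compound 2, `CS(=O)(=O)c1cc(C(=O)N=C(N)N)ccc1N1CCCCC1`, gives 130 nM in this assay.
Compound 3, `CCc1cc(Oc2cccnc2)c(S(C)(=O)=O)cc1C(=O)N=C(N)N`, gives 27 nM in this assay.

Compound 4, `CCc1cc(N2CCCCC2)c(S(C)(=O)=O)cc1C(=O)N=C(N)N`, has not yet been measured. It differs from compound 3 by piperidin-1-yl in place of (pyridin-3-yl)oxy on an aromatic carbon. This kind of change has been measured once before: compound 2 differs from compound 1 by piperidin-1-yl in place of (pyridin-3-yl)oxy on an aromatic carbon, and the step was a 1.7-fold higher number from compound 1 to compound 2 (0.23 log units; within the scatter). The two cores themselves differ by ethyl in place of hydrogen on an aromatic carbon, so the place of the change in compound 3 is also meta to an ethyl group, which it is not in compound 1; the change is therefore the same kind of change rather than the same one. Among the three measured compounds, compound 3 gives the lowest number. Because a 1.7-fold higher number from compound 1 to compound 2 (0.23 log units; within the scatter) stayed within the scatter, compound 4 is expected to show a step of similar size, a 1.7-fold higher number from compound 3 to compound 4 (0.22 log units; within the scatter). Compound 4 is accordingly estimated at 45 nM, with a range from 20 nM to 110 nM.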

Compound 4, half-maximal inhibitory concentration: 25 nM
The estimate for compound 4 lay 1.8-fold (0.26 log units) above the measured number, and the stated range covers the measured number.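

Replacing (pyridin-3-yl)oxy with piperidin-1-yl on the ethyl-bearing core gives a 1.1-fold lower number from compound 3 to compound 4 (0.03 log units; within the scatter), and in this assay this step agrees with the same replacement on the core of compound 1: the same change on two cores in this assay, a 1.7-fold higher number (0.23 log units; within the scatter) from compound 1 to compound 2 and a 1.1-fold lower number (0.03 log units; within the scatter) from compound 3 to compound 4, 1.8-fold (0.27 log units) apart, within the scatter of two such steps. Adding the ethyl group to the piperidin-1-yl compound gives a 5.2-fold lower number from compound 2 to compound 4 (0.72 log units; beyond the scatter), which likewise agrees with the ethyl step seen with (pyridin-3-yl)oxy: the same change on two cores in this assay, a 2.8-fold lower number (0.45 log units; beyond the scatter) from compound 1 to compound 3 and a 5.2-fold lower number (0.72 log units; beyond the scatter) from compound 2 to compound 4, 1.8-fold (0.27 log units) apart, within the scatter of two such steps. Together these results show that, across these two cores, the two changes combine about as the single steps suggest, but the four compounds form one small square of comparisons and do not establish a rule for any other core, and neither replacement step on its own lies beyond the scatter.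

The compounds shown leave open how an open-chain amine such as dimethylamino or a morpholine ring would compare with piperidin-1-yl at this place. They also leave open whether a longer chain, such as propyl or butyl, in place of the ethyl group would lower the number further.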